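This account rests on a few compounds, and the source may have more. Where it says the series, first, only, none or still open, it means among the compounds named here.

Three compounds sharing one core were examined in an assay on CHO cells for displacement of a labelled ligand from adenosine receptor A3 (Homo sapiens), read by scintillation counting, with a stated time of 120 min, tested at 10 uM; a higher number here means more inhibition at the concentration tested (going by the name of the read-out), a lower number less inhibition. Compound 1 `Nc1scc(CN2CCN(c3cccc(Cl)c3Cl)CC2)c1C(=O)c1ccc(Cl)cc1` gives 0% there, compound 2 `Nc1scc(CN2CCN(c3ccc([N+](=O)[O-])cc3)CC2)c1C(=O)c1ccc(Cl)cc1` gives 2%, and compound 3 `Nc1scc(CN2CCN(c3cccnc3)CC2)c1C(=O)c1ccc(Cl)cc1` gives 0%. On the bare numbers compound 2 stands highest of the three, yet its steps to the others, a number 2 percentage points higher from compound 1 to compound 2 (within the scatter) and a number 2 percentage points lower from compound 2 to compound 3 (within the scatter), both lie within the scatter, so no order among them can be claimed. Compound 4 `Nc1scc(CN2CCN(c3ccc(F)c(F)c3)CC2)c1C(=O)c1ccc(Cl)cc1` has not been measured; it differs from compound 2 in one place: 3,4-difluorophenyl in place of 4-nitrophenyl on an amine nitrogen in a ring. Both measured steps that vary this same position on the ring nitrogen left the number within the scatter, so no step beyond the scatter is expected here either. Compound 4 is therefore estimated at 1%, between -6% and 9%, which means an expected step of a number 1 percentage points lower from compound 2 to compound 4 (within the scatter).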

Compound 4, a percentage reported as inhibition, at one concentration (the size of the read-out at that concentration, not a potency): 1%
Compound 4: the middle estimate sits on the measured number at the digits printed, within the range that was stated.
By their numbers in this assay, from the lowest: compounds 1, 3, 4 and 2 (each within the scatter of the next).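

In this assay, 3,4-difluorophenyl, with 0 hydrogen-bond acceptors against 2 in 4-nitrophenyl, gives a number 1 percentage points lower from compound 2 to compound 4 (within the scatter), so this difference in the counts comes with no step beyond the scatter. The other new steps, a number 1 percentage points higher from compound 3 to compound 4 (within the scatter) and a number 1 percentage points higher from compound 1 to compound 4 (within the scatter), agree: all four aromatic groups at this position read alike, and none goes against this. No available evidence bears on why the position behaves this way.

From the compounds shown here alone, it remains open whether a benzyl group, a longer alkyl chain or a carboxylic acid on this nitrogen would give a step beyond the scatter. Going by these compounds, whether any change elsewhere on the shared core would do so also stays open.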